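This account rests on a few compounds, and the source may have more. Where it says the series, first, only, none or still open, it means among the compounds named here.

Compound 3 `CC1(C)CC(=O)C2=C(C1)NC(c1ccccc1)=CC2c1ccc(F)cc1` gives 7.38% in an assay on isolated protein for inhibition of glucose-6-phosphatase catalytic subunit 1 (Homo sapiens), read by inositol phosphate accumulation, with a stated time of 30 min, tested at 100 uM; a higher number here means more inhibition at the concentration tested (going by the name of the read-out), a lower number less inhibition. Its closest neighbour on the numbers is compound 1 `CC1(C)CC(=O)C2=C(C1)NC(c1ccccc1)=CC2c1ccc(Cl)cc1`, which gives 7.16% in this assay; the two values sit within the scatter of each other. Compound 2 `COc1ccc(C2C=C(c3ccccc3)NC3=C2C(=O)CC(C)(C)C3)cc1`, which carries a methoxyphenyl group instead, is reported in this assay as "not active" (no number reported), without a number.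

The change from compound 3 to compound 4 `CC1(C)CC(=O)C2=C(C1)NC(c1ccccc1)=CC2c1ccco1` is furan-2-yl in place of 4-fluorophenyl on a saturated ring carbon. Among the compounds with values here, the one measured step that touches this position, a number 0.2 percentage points higher from compound 1 to compound 3 (within the scatter), exchanged only the halogen on the aromatic ring and stayed within the scatter. Within the data shown here, no measured step exchanges the whole ring for a five-membered one, so nothing in the data suggests a step beyond the scatter in either direction, and all numbers so far are low.

Compound 4 is therefore expected to give about 6% in this assay, within a range of 0% to 16%, an expected step of a number 1.4 percentage points lower from compound 3 to compound 4 (within the scatter).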

Compound 4, a percentage reported as inhibition, at one concentration (the size of the read-out at that concentration, not a potency): 11.4%
Compound 4: the middle estimate sits 5.4 percentage points below what was measured; the measured number falls inside the stated range.
By their numbers in this assay, from the lowest: compounds 1, 3 and 4 (each within the scatter of the next).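

In this assay, within the data shown here, the only earlier step at this position exchanged a halogen on the ring, whereas this change replaces the whole 4-fluorophenyl with furan-2-yl, a five-membered aromatic ring with 1 hetero atom. Even so, the result is a number 4 percentage points higher from compound 3 to compound 4 (within the scatter) and likewise a number 4.2 percentage points higher from compound 1 to compound 4 (within the scatter), so among these three compounds neither the ring nor its halogen moves the number beyond the scatter, while compound 2, reported without a number, gives no step that can be read. Nothing measured here accounts for this result.

The compounds shown leave open whether a saturated group such as cyclohexyl, or a ring bearing an amine or a carboxylic acid, would give a step beyond the scatter on this saturated ring carbon. They also leave open what happens when the phenyl group, shared by all four compounds, is replaced by a pyridyl ring.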